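A Fluoro Swap at the Assay Limit

This account rests on a few compounds, and the source may have more. Where it says the series, first, only, none or still open, it means among the compounds named here.

Measured in an ADME assay on CEMx174 cells (Homo sapiens) for cytotoxicity (on this read-out higher numbers stand for lower toxicity in this test and lower numbers for higher toxicity in this test), each value a limit and not a number:
compound 1 `CCC1=C(C(=O)OCC2CCCCC2)C(c2ccc([N+](=O)[O-])cc2)NC(=O)N1`: > 10000 nM
compound 2 `CCC1=C(C(=O)OCC2CCCCC2)C(c2ccc(NC(C)=O)cc2)NC(=O)N1`: > 10000 nM

Compound 2 gives > 10000 nM, which is a limit and not a number. Compound 3 `CCC1=C(C(=O)OCC2CCCCC2)C(c2ccc(F)cc2)NC(=O)N1` is compound 2 with fluoro in place of acetamido on an aromatic carbon. Among the compounds with values here, the only measured step at this place is a step that the two limits leave unreadable from compound 1 to compound 2, so it gives no size to carry over. Both measured compounds share one ceiling: the limit of > 10000 nM in this assay, at which 2 of the 2 values shown sit. No change beyond the scatter is expected in this assay, in either direction, and the estimated step is a step that the limit leaves unreadable from compound 2 to compound 3. For compound 3 the estimate is 15000 nM. The expected range runs from 6000 nM to 40000 nM.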

Compound 3, half-maximal cytotoxic concentration: > 10000 nM
Compound 3: only a limit was reported; the forecaster's own chance of this, stated with the estimate: 85%; the middle value does not contradict the limit.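

Compound 3 gives > 10000 nM, a limit and not a number. Within the data shown here, no step among compound 1, compound 2 and compound 3 can therefore be read: the limit of > 10000 nM in this assay, at which 3 of the 3 values shown sit. As far as these compounds go, whether nitro, acetamido and fluoro differ at all in this assay stays open.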